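Ethoxy to methoxy on the aryl group of compound 1

The source may report more compounds than this note shows. Statements on the series, on what has been measured and on what is new or still open speak of the compounds shown alone.

Measured compounds:
compound 1 `C=C(Br)C(=O)Nc1cccc(-c2cn3nc(-c4ccc(OCC)cc4)sc3n2)c1`, 790 nM
compound 2 `Nc1cccc(-c2cn3c(-c4ccc(Cl)cc4)csc3n2)c1`, 22000 nM
compound 3 `C=C(Br)C(=O)Nc1cccc(-c2cn3c(-c4ccccc4)csc3n2)c1`, 1300 nM

In a functional assay on L1210 cells (Mus musculus) for inhibition, read by cell counting, with a stated time of 2 days (a lower number here means a stronger inhibitor, a higher number a weaker inhibitor), compound 1 gives 790 nM, the lowest of the three numbers. Compound 3 gives 1300 nM, which lies within the scatter of compound 1, so no order between these two can be stated. Compound 2, which carries the free amine instead of the bromoacrylamide, gives 22000 nM, a gap beyond the scatter. Among the measured compounds shown here, with only three compounds no wider pattern is claimed.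

Compound 4 `C=C(Br)C(=O)Nc1cccc(-c2cn3nc(-c4ccc(OC)cc4)sc3n2)c1` is not yet measured. It differs from compound 1 in one place: hydrogen in place of methyl on a saturated chain carbon bound to an oxygen on an aromatic ring. Nothing else in the molecule changes, and the bromoacrylamide that separates compounds 1 and 3 from compound 2 is retained.

In this assay the step of a 1.1-fold higher number from compound 1 to compound 4 (0.06 log units; within the scatter) is expected to be small, with no direction beyond the scatter, since the change is one carbon on the alkoxy chain. Compound 4 is therefore estimated at 900 nM, with a likely range from 400 nM to 2000 nM.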

Compound 4, half-maximal inhibitory concentration: 940 nM
Beside the measured number, compound 4's estimate is 1.0-fold (0.02 log units) below it; the measured number falls inside the stated range.
By their numbers in this assay, from the lowest: compounds 1, 4 and 3 (each within the scatter of the next); then compound 2.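

In this assay the change from 4-ethoxyphenyl to 4-methoxyphenyl gives a 1.2-fold higher number from compound 1 to compound 4 (0.08 log units; within the scatter), which lies within the scatter. Among the compounds shown here, this is the first pair that differs in one place, so the alkoxy group can now be read on its own: with the bromoacrylamide and the shared core held fixed, ethoxy and methoxy cannot be told apart in this read-out. No measurement at hand offers an explanation for this result.

Still open, as far as these compounds go, is how a butoxy chain, a hydroxyl group or a dimethylamino group would read on this aryl ring in place of these two alkoxy groups. Also open, from the compounds shown here alone, is what the free amine in place of the bromoacrylamide would give on the core of compound 1.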